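The source may report more compounds than this note shows. Statements on the series, on what has been measured and on what is new or still open speak of the compounds shown alone.

Working notes on the series, all on one shared core. In an ADME assay on HL-60 cells (Homo sapiens) for cytotoxicity, read by MTT assay, with a stated time of 24 h (a higher number here means a weaker inhibitor, a lower number a stronger inhibitor), compound 1 (`CC(C)CN(C)Cc1ccc(C2CCCN(C)C2)cc1`) gives > 50000 nM as a limit, not a number. Compound 2 (`CC(C)CCCN(C)Cc1ccc(C2CCCN(C)C2)cc1`) gives > 50000 nM as a limit too. Compound 3 (`CN(Cc1ccc(Cl)cc1)Cc1ccc(C2CCCN(C)C2)cc1`) gives > 50000 nM and this is again a limit, so it has no exact standing within the set. Together these sit at the limit of > 50000 nM in this assay, at which 3 of the 3 values shown sit, with no number among them.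

The next change leads to compound 4 (`CN(C/C=C/c1ccccc1)Cc1ccc(C2CCCN(C)C2)cc1`) with 2-phenylethenyl in place of 4-chlorophenyl on a saturated chain carbon bound to an amine nitrogen. Three measured steps at this same place bear on it: a step that the two limits leave unreadable from compound 1 to compound 2 along with a step that the two limits leave unreadable from compound 1 to compound 3 and a step that the two limits leave unreadable from compound 2 to compound 3 and none of them gives a size. Exchanges among isopropyl, isopentyl and 4-chlorophenyl have therefore shown no readable effect here. Since compound 3 stands at the limit > 50000 nM the expectation in this assay is no step beyond the scatter, in either direction. The expected change is a number no higher from compound 3 to compound 4 (the limit leaves the size open) as an estimate only. For compound 4 the estimated value is 50000 nM with an expected range from 20000 nM to 100000 nM and a report as a limit is the likeliest outcome.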

Compound 4, half-maximal inhibitory concentration: > 50000 nM
Compound 4: only a limit was reported (the forecaster's own chance of this, stated with the estimate: 75%); the middle value sits exactly at the limit.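

Compound 4 is again reported only as a limit, so its steps from compound 1, compound 2 and compound 3 cannot be read. Compound 1, compound 2, compound 3 and compound 4 all stand at one reported value: the limit of > 50000 nM in this assay, at which 4 of the 4 values shown sit.

The compounds shown leave open whether any group at this place changes the result in this assay.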